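The source may hold more compounds than are shown below. What is called first, only, known or untested is meant among the compounds shown, and "the series" means these compounds.

- compound 1 `CC(C)[C@H](N)C(=O)N[C@@H](CCC(=O)C=[N+]=[N-])C(=O)OCc1c[nH]c2ccccc12`: 0%
- compound 2 `Cc1oc(=O)oc1COC(=O)N[C@@H](CCC(=O)C=[N+]=[N-])C(=O)OC(C)C`: 0%

In an ADME assay on a cell-free system (plasma, Mus musculus) for metabolic stability, read by LC-MS, with a stated time of 60 min, tested at 10 uM (a lower number here means that less of the compound is left, a higher number that more of the compound is left), compound 1 gives 0%, level with compound 2 at 0% within the scatter. The next compound is compound 3 `CC[C@H](N)C(=O)N[C@@H](CCC(=O)C=[N+]=[N-])C(=O)OCc1c[nH]c2ccccc12`, not yet measured. The change from compound 1 is hydrogen in place of methyl on a saturated chain carbon bound to two saturated chain carbons, which reads as isopropyl to ethyl. Among the measured compounds shown here, no measured pair shows the effect of this change. Compound 1 stands at 0%, so no step beyond the scatter is expected. The expected step is no change at the digits printed from compound 1 to compound 3 (within the scatter). For compound 3 the estimated value is 0%, with an expected range of 0% to 5%.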

Compound 3, percent of the compound remaining: 0%
Beside the measured number, compound 3's estimate shows no gap at the digits printed, and the stated range covers the measured number.
By their numbers in this assay, from the lowest: compounds 1, 2 and 3 (each within the scatter of the next).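

In this assay, among the compounds shown here, isopropyl to ethyl on a saturated chain carbon bound to two saturated chain carbons gives no change at the digits printed from compound 1 to compound 3 (within the scatter), the first matched pair at this position. With compound 3 at 0%, the pair shows no separation between these two side chains, but a read-out at this value leaves no room to see any loss. Nothing measured bears on why the compounds read this way.

From the compounds shown here alone, it remains open whether a phenyl group or a carboxylic acid at this position would leave any compound remaining.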